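Enantiomer swap in a cyclohexene amide pair

The compounds below may be only part of what the source reports. "The series", "measured", "known", "first", "only" and "open" are said of these compounds alone.

Measured so far:
compound 1 `CONC(=O)[C@@H]1CC=C(CCC=C(C)C)C[C@H]1c1ccccc1` 2700 nM
compound 2 `CON(C)C(=O)[C@H]1CC=C(CCC=C(C)C)C[C@@H]1c1ccccc1` 300 nM

In an assay on isolated protein for inhibition of Apoptosis regulator Bcl-2 (Homo sapiens), read by fluorescence polarization, with stated times of 5 min and 10 min (on this read-out lower numbers stand for stronger inhibition and higher numbers for weaker inhibition), compound 2 holds the lowest of the two numbers; the nearest is compound 1, whose number is higher by a margin beyond the scatter. Compound 3 `CON(C)C(=O)[C@@H]1CC=C(CCC=C(C)C)C[C@H]1c1ccccc1` is not yet measured. Its relation to compound 2 is the two compounds have the same atoms and bonds and differ only in configuration as drawn: 2 of 2 stereo elements differ (all stereocentres are inverted: mirror images); a stereocentre at a saturated ring carbon is drawn S in compound 2 and R in compound 3; a stereocentre at a saturated ring carbon is drawn S in compound 2 and R in compound 3: the two compounds have the same atoms and bonds and differ only in configuration as drawn, all stereocentres inverted, mirror images. Within the data shown here, no measured pair in this assay shows such a change, so the direction is open; a weakening step is expected, giving a 5.0-fold higher number from compound 2 to compound 3 (0.70 log units; beyond the scatter) with wide uncertainty. For compound 3 the estimate in this assay is 1500 nM, between 300 nM and 10000 nM.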

Compound 3, inhibition constant: > 23000 nM
Compound 3: no number, only a limit; the forecaster's own chance of this, stated with the estimate: 10%; middle value at least 15-fold (1.18 log units) away from the limit.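

In this assay compound 3 gives > 23000 nM, a limit of the assay and not a number. Inverting both stereocentres with the atoms and bonds unchanged gives an at least 76-fold higher number from compound 2 to compound 3 (1.88 log units; beyond the scatter), so the configuration as drawn decides this pair. With the configuration held as drawn, methyl in place of hydrogen on an amide-type nitrogen gives an at least 8.5-fold higher number from compound 1 to compound 3 (0.93 log units; beyond the scatter).

On these data alone, the separate share of each stereocentre remains open, as both change together here. Also open, as far as these compounds go, is how an ethyl group on the amide nitrogen, or a carboxylic acid in place of the amide, would read out in the configuration of compound 2.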